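Pyridin-4-yl in place of dichlorophenyl: an expected loss

A few compounds are considered here, and "the series" means these few. Any claim that something is new, unique, unknown or untested is made for them only; others in the source may bear on it.

Three measured compounds share one core and differ only in the ring that sits on a saturated chain carbon bound to a nitrogen on an aromatic ring. Compound 1 `CNc1nc(NCc2ccc(Cl)cc2Cl)cc(-c2ccccn2)n1` carries a 2,4-dichlorophenyl there and, in a functional assay on HEK293 cells for agonist activity at G-protein coupled receptor 39 (Homo sapiens), read by inositol phosphate accumulation (a lower number here means that less compound is needed, a higher number that more compound is needed for the effect), compound 1 gives 0.8 nM, the lowest number of the three. Compound 2 `CNc1nc(NCc2ccc(NC(C)=O)cc2)cc(-c2ccccn2)n1` gives 5 nM and compound 3 `CNc1nc(NCc2ccc(NS(C)(=O)=O)cc2)cc(-c2ccccn2)n1` gives 3 nM. Going by the values given here, the only step between two measured compounds that differ in a single place is a 1.7-fold lower number from compound 2 to compound 3 (0.22 log units; within the scatter), which swaps a substituent on that ring without touching the ring itself. Compound 4 `CNc1nc(NCc2ccncc2)cc(-c2ccccn2)n1` is not yet measured; it differs from compound 1 by pyridin-4-yl in place of 2,4-dichlorophenyl on a saturated chain carbon bound to a nitrogen on an aromatic ring. Among the compounds with values here, no measured step exchanges the whole ring, so the step from compound 2 to compound 3 offers little guidance, and the values only show that compound 1 sits lowest while both other rings give higher numbers. Compound 4 is expected to need more compound, an upward step of a 38-fold higher number from compound 1 to compound 4 (1.57 log units; beyond the scatter). The estimate for compound 4 is 30 nM, with a range from 5 nM to 200 nM.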

Compound 4, half-maximal effective concentration: 87 nM
For compound 4 the middle estimate is 2.9-fold (0.46 log units) below the measured one, and the stated range covers the measured number.
By their numbers in this assay, from the lowest: compound 1; then compounds 3 and 2 (each within the scatter of the next); then compound 4.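

In this assay, going by these compounds alone, exchanging the whole ring gives a 110-fold higher number from compound 1 to compound 4 (2.04 log units; beyond the scatter) as the first measured step of this kind at this place, whereas the substituent swap gave only a 1.7-fold lower number from compound 2 to compound 3 (0.22 log units; within the scatter) and stayed within the scatter. So the ring on a saturated chain carbon bound to a nitrogen on an aromatic ring cannot be exchanged freely here, at least not in this form: the step removes both chlorine atoms and also brings in a ring nitrogen that counts as a hydrogen-bond acceptor, and this single pair cannot separate those two changes. Nothing measured here explains the size of the rise.

Still open, on these data alone, is whether an unsubstituted phenyl ring would give a number closer to that of compound 1 or that of compound 4. Also open, as far as these compounds go, is whether a pyridin-3-yl ring, or a pyridine ring carrying a chlorine, would recover any of the loss.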